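Weak cytotoxicity and a larger aromatic group on the sulfur

This account rests on a few compounds, and the source may have more. Where it says the series, first, only, none or still open, it means among the compounds named here.

Of the compounds shown here, three sharing one core have been measured in a functional assay on HeLa cells (Homo sapiens) for cytotoxicity, read by MTT assay, with a stated time of 72 h; on this read-out higher numbers stand for weaker inhibition and lower numbers for stronger inhibition. Compound 1 `Cc1cc(S(=O)(=O)/N=C(\N)n2nccc2-c2ccccc2)c(SCc2cccc(Cl)c2)cc1Cl` gives 10000 nM, compound 2 `Cc1cc(S(=O)(=O)/N=C(\N)n2nccc2-c2ccccc2)c(SCc2ccccc2)cc1Cl` gives 5000 nM, and compound 3 `Cc1cc(-c2ccccc2)n(/C(N)=N/S(=O)(=O)c2cc(C)c(Cl)cc2SCc2ccccc2)n1` gives 5000 nM. All three numbers sit at the weak end of what such a test reports. Compound 2 stands level with compound 3 at the digits shown, and the two together hold the lowest numbers of the three; compound 1 is the furthest from compound 2, yet even that gap, a 2.0-fold lower number from compound 1 to compound 2 (0.30 log units; within the scatter), stays inside the usual scatter.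

The new compound 4 `Cc1cc(S(=O)(=O)/N=C(\N)n2nccc2-c2ccccc2)c(SCc2cccc3ccccc23)cc1Cl` arises from compound 2 by one change: naphthalen-1-yl in place of phenyl on a saturated chain carbon bound to a sulfur. Among the compounds with values here, no measured step makes this exact change. The nearest comparison is the step from compound 1 to compound 2, which also altered the ring bound to the sulfur through its saturated chain carbon, and it moved the number by a 2.0-fold lower number from compound 1 to compound 2 (0.30 log units; within the scatter). The step from compound 2 to compound 3, no change at the digits printed from compound 2 to compound 3 (within the scatter), altered the core elsewhere and showed no change. Both bearings point to small movements only.

Compound 4 is therefore expected to remain close to compound 2 in this assay, at an estimated 5000 nM, with a range from 1500 nM to 15000 nM, which corresponds to an expected step of no change at the digits printed from compound 2 to compound 4 (within the scatter).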

Compound 4, half-maximal inhibitory concentration: 3000 nM
Beside the measured number, compound 4's estimate is 1.7-fold (0.22 log units) above it; the range from low to high includes it.
By their numbers in this assay, from the lowest: compounds 4, 2, 3 and 1 (each within the scatter of the next, the first and the last beyond it).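

The position on a saturated chain carbon bound to a sulfur accepts a clearly larger group: naphthalen-1-yl brings 10 heavy atoms and two aromatic rings where phenyl has 6 heavy atoms and one ring, yet this assay shows a 1.7-fold lower number from compound 2 to compound 4 (0.22 log units; within the scatter), so the added ring leaves the result no different from that of phenyl beyond normal variation. Against the 3-chlorophenyl group, the same position yields the first step in this small set to pass the scatter, a 3.3-fold lower number from compound 1 to compound 4 (0.52 log units; beyond the scatter), although this step remains modest and compound 4 still sits at the weak end of the scale. No supporting measurement is available to explain either step.

As far as these compounds go, the groups compared at this position are all aromatic rings of carbon, with or without a chloro substituent, so it remains open how an amine or a carboxylic acid on the ring would read in this test. Also open, from the compounds shown here alone, are the isomeric naphthalen-2-yl group, a longer chain linking the ring to the sulfur, and whether naphthalen-1-yl behaves the same way on the methyl-bearing core of compound 3.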